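From Compound 2 to Compound 3: One Hydroxyl Fewer

The source may report more compounds than this note shows. Statements on the series, on what has been measured and on what is new or still open speak of the compounds shown alone.

In a functional assay (Mus musculus) for inhibition, with a stated time of 5 days (on this read-out higher numbers stand for weaker inhibition and lower numbers for stronger inhibition), compound 1 `O=C(O)/C=C/c1cn(-c2ccc(O)cc2)nc1-c1ccc(O)cc1` reaches only the limit of the assay, > 100000 nM. Among the compounds with values here, compound 2 `CCOC(=O)/C=C/c1cn(-c2ccc(O)cc2)nc1-c1cc(O)ccc1O` gives 12000 nM in this assay, the sole measured number among the two values recorded. The other value recorded, that of compound 1, is a limit (the limit of > 100000 nM in this assay, at which 1 of the 2 values shown sits). Compound 1 and compound 2 differ in more than one place, so their two values show no more than that one is a limit and the other a number. Compound 3 `CCOC(=O)/C=C/c1cn(-c2ccc(O)cc2)nc1-c1ccc(O)cc1` has not yet been measured; it arises from compound 2 by the change (4-hydroxyphenyl in place of 2,5-dihydroxyphenyl on an aromatic carbon). Within the data shown here, no measured step of this kind exists, so the size of the step in this assay is open, though a loss of inhibition beyond the usual scatter appears the more likely direction. Compound 3 is therefore estimated at 30000 nM, within a range from 8000 nM to 100000 nM, an expected step of a 2.5-fold higher number from compound 2 to compound 3 (0.40 log units; beyond the scatter).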

Compound 3, half-maximal inhibitory concentration: 25000 nM
Compound 3: middle estimate off by 1.2-fold (0.08 log units), on the high side; measured number inside the range.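

Within the data shown here, on the aromatic carbon next to the ring nitrogen, the change to 4-hydroxyphenyl from 2,5-dihydroxyphenyl gives the first reading of a single change in this assay: it brings a 2.1-fold higher number from compound 2 to compound 3 (0.32 log units; beyond the scatter), a modest loss of inhibition. Compound 3 also connects to compound 1 through one place, and ethyl in place of hydrogen on an oxygen next to a carbonyl group brings an at least 4.0-fold lower number from compound 1 to compound 3 (0.60 log units; beyond the scatter), a gain in inhibition of at least modest size. The value for compound 1 is a limit, so this step gives only a bound: the limit of > 100000 nM in this assay, at which 1 of the 3 values shown sits.

As far as these compounds go, how an amine or a methoxy group would compare with the hydroxyl groups on this aromatic ring remains open. So does the effect of a longer chain in place of the ethyl on that oxygen.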